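This account rests on a few compounds, and the source may have more. Where it says the series, first, only, none or still open, it means among the compounds named here.

In a physicochemical assay for solubility (on this read-out lower numbers stand for lower solubility and higher numbers for higher solubility), compound 3 (`C[C@H]1C(=O)N(C)C=Cc2cc(CC3CCOCC3)ccc21`) reads >= 111 ug/mL as a limit of the assay, not a number. Compound 1 (`CCOc1ccc2c(c1)C=CN(C)C(=O)C2C`) reads >= 120 ug/mL as a limit too. Compound 2 (`CC1C(=O)N(C)C=Cc2cc(OCC(C)(C)O)ccc21`) reads >= 131 ug/mL as a limit too. Compound 4 (`C[C@H]1C(=O)N(C)C=Cc2cc(C(O)CO)ccc21`) carries 1,2-dihydroxyethyl in place of (oxan-4-yl)methyl on an aromatic carbon. Among the compounds with values here, the only measured step that bears on this, a step that the two limits leave unreadable from compound 1 to compound 2 with 1-hydroxy-1-methylethyl in place of methyl on a saturated chain carbon, offers no size to carry over. The expected change is a step that the limit leaves unreadable from compound 3 to compound 4 in this assay and nothing beyond the usual scatter is expected in either direction. For compound 4 the estimated value is 125 ug/mL with 95 ug/mL to 170 ug/mL as the expected range.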

Compound 4, solubility: >= 101 ug/mL
Compound 4: only a limit was reported (the forecaster's own chance of this, stated with the estimate: 75%); the middle value does not contradict the limit.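

Within the data shown here, compound 3 and compound 4 are both reported only as limits in this assay, so no step between them can be read. The compounds shown leave open whether 1,2-dihydroxyethyl in place of (oxan-4-yl)methyl changes this read-out at all.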